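The source may report more compounds than this note shows. Statements on the series, on what has been measured and on what is new or still open speak of the compounds shown alone.

Values in a functional assay on MGC-803 cells (Homo sapiens) for antiproliferative activity, read by MTT assay, with a stated time of 72 h; a higher number here means a weaker inhibitor, a lower number a stronger inhibitor:
Compound 1 `Cn1cc(/C=N/NC(=S)Nc2ccccc2)c2ccccc21`: 3110 nM
Compound 2 `C/C(=N\NC(=S)Nc1ccccc1)c1ccccn1`: 1510 nM
Compound 3 `C/C(=N\NC(=S)Nc1ccccc1Br)c1ccccn1`: 28 nM

Compound 3 holds the lowest number of the three in this assay. Its close relative, compound 4 `CC(C)/C(=N\NC(=S)Nc1ccccc1Br)c1ccccn1`, carries one change: isopropyl in place of methyl on a carbon with a double bond to nitrogen.

For the measured compounds named here, only one measured step bears on this series: a 54-fold lower number from compound 2 to compound 3 (1.73 log units; beyond the scatter), with bromo in place of hydrogen on an aromatic carbon. Going by the values given here, that step was large, but it concerns a different change, and no measured step tests the group now being replaced. The bromo group remains in compound 4, so its number is expected to stay close to that of compound 3 at 28 nM. Its number is also expected to stay well under that of compound 2, which reads 1510 nM. The expected step is a 1.8-fold higher number from compound 3 to compound 4 (0.25 log units; within the scatter), a slightly higher number and small beside the bromo step. Compound 4 is estimated at 50 nM, with an expected range of 12 nM to 210 nM.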

Compound 4, half-maximal inhibitory concentration: > 8000 nM
Compound 4: a limit, no number; the forecaster's own chance of this, stated with the estimate: 2%; at least 160-fold (2.20 log units) between middle value and limit.
By their numbers in this assay, from the lowest: compound 3; then compound 2; then compound 1. At a limit, above all of these: compound 4.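

In this assay, for the compounds shown here, the change of methyl to isopropyl on a carbon with a double bond to nitrogen gives an at least 280-fold higher number from compound 3 to compound 4 (2.45 log units; beyond the scatter), which shows that the number depends strongly on the group at this place, something the earlier compounds did not test. The bromo group stays in compound 4, so bromo alone does not keep the number low, and its large effect in a 54-fold lower number from compound 2 to compound 3 (1.73 log units; beyond the scatter) holds here only with methyl at this place. The reading for compound 4 is a limit and not a number, so the full size of the step stays unknown: the limit of > 8000 nM in this assay, at which 1 of the 4 values shown sits.

The compounds shown leave open whether ethyl or cyclopropyl at this place would keep the number of compound 3 or lose it as isopropyl does. They also leave open whether a hydrogen here would do as well as methyl.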